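The source may report more compounds than this note shows. Statements on the series, on what has been measured and on what is new or still open speak of the compounds shown alone.

Working notes on the series. Compound 1, `CCC[C@@H](OC(C)=O)C1=C(Br)[C@@](C)(OC)OC1=O`, is the starting point. In a functional assay on Lu1 cells (Homo sapiens) for cytotoxicity (on this read-out higher numbers stand for an effect only at larger amounts of compound and lower numbers for an effect already at smaller amounts), compound 1 gives only a limit of the assay, > 20 ug/mL. Among the measured compounds shown here, the sole measured neighbour is compound 2, `CCC[C@@H](OC(C)=O)C1=C(Br)[C@@](CI)(OC)OC1=O`, which carries iodo in place of hydrogen on a saturated chain carbon bound to a saturated ring carbon. In this assay compound 2 likewise gives only a limit, > 20 ug/mL. The step that the two limits leave unreadable from compound 1 to compound 2 cannot be read because the limit of > 20 ug/mL in this assay, at which 2 of the 2 values shown sit, is where both values sit.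

Compound 3, `CCC[C@@H](OC(C)=O)C1=C(Br)[C@](C)(OC)OC1=O`, differs from compound 1 as follows: the two compounds have the same atoms and bonds and differ only in configuration as drawn: 1 of 2 stereo elements differ; a stereocentre at a saturated ring carbon is drawn S in compound 1 and R in compound 3. For the measured compounds named here, no measured step concerns a change of configuration, and the one measured step is itself unreadable, so nothing here supports a direction beyond the scatter. The expectation for compound 3 in this assay is another limit rather than a number, estimated at 30 ug/mL with a range from 15 ug/mL to 100 ug/mL. The step that the limit leaves unreadable from compound 1 to compound 3 implied by this estimate is expected to be essentially none.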

Compound 3, concentration for half-maximal effect: > 20 ug/mL
Compound 3 gave a limit, no number; the forecaster's own chance of this, stated with the estimate: 85%; the middle value is on the limit's open side.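

In this assay compound 3 gives only a limit, > 20 ug/mL. The step from compound 1 to compound 3 cannot be read, because the values share one limit: the limit of > 20 ug/mL in this assay, at which 3 of the 3 values shown sit.

The compounds shown leave open whether the configuration or the iodo affects cytotoxicity, since none gives a number.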